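Homologating the aryl ether in the hydroxamate series

The compounds below may be only part of what the source reports. "The series", "measured", "known", "first", "only" and "open" are said of these compounds alone.

Compound 1 `Cc1ccc2nc(NC(=O)CCCCC(=O)NO)sc2c1` gives 13.3 ug/mL in a functional assay on ASPC1 cells (Homo sapiens) for cytotoxicity; a higher number here means a weaker inhibitor, a lower number a stronger inhibitor. Compound 2 `COc1ccc2nc(NC(=O)CCCCC(=O)NO)sc2c1`, which carries methoxy in place of methyl on an aromatic carbon, gives 23.9 ug/mL in this assay; the step of a 1.8-fold higher number from compound 1 to compound 2 (0.25 log units; within the scatter) stays within the scatter. Among the two numbers so far, compound 2 has the highest, and its nearest neighbour is compound 1, a gap that the scatter covers, so no order between the two can be read.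

Compound 3 `CCOc1ccc2nc(NC(=O)CCCCC(=O)NO)sc2c1` differs from compound 2 by methyl in place of hydrogen on a saturated chain carbon bound to an oxygen on an aromatic ring. Within the data shown here, the only measured step, that from methyl to methoxy, bears on it indirectly and was itself within the scatter; no step extending the ether chain has been measured. On that basis the change is expected to move this assay by nothing beyond the scatter, and the step of a 1.0-fold higher number from compound 2 to compound 3 (0.02 log units; within the scatter) is the expected outcome. Compound 3 is therefore estimated at 25 ug/mL, with a range from 12 ug/mL to 50 ug/mL.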

Compound 3, half-maximal inhibitory concentration: 16.7 ug/mL
For compound 3 the middle estimate is 1.5-fold (0.18 log units) above the measured one; measured number inside the range.
By their numbers in this assay, from the lowest: compounds 1, 3 and 2 (each within the scatter of the next).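

Extending methoxy to ethoxy, with methyl in place of hydrogen on a saturated chain carbon bound to an oxygen on an aromatic ring, gives a 1.4-fold lower number from compound 2 to compound 3 (0.16 log units; within the scatter) in this assay; this is the first direct read on ether chain length at this position, and it shows no change. The step of a 1.3-fold higher number from compound 1 to compound 3 (0.10 log units; within the scatter) stays within the scatter too, so methyl, methoxy and ethoxy all lie within the scatter of one another and no order among the three can be read. No supporting data are available to explain this flat result.

As far as these compounds go, whether a longer ether such as propoxy or butoxy would move the number beyond the scatter remains open. So does whether an amine or a carboxylic acid on the same aromatic carbon would do so.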